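The compounds below may be only part of what the source reports. "The series", "measured", "known", "first", "only" and "open" are said of these compounds alone.

Measured so far:
compound 1, `CC(C)=CC[C@@H](OC(=O)C1CCCO1)C1=CC(=O)c2c(O)ccc(O)c2C1=O`, giving 17000 nM in a functional assay on HeLa cells (Homo sapiens) for cytotoxicity, read by MTT assay; a higher number here means a weaker inhibitor, a lower number a stronger inhibitor;
compound 2, `CCCC(C)(O)CC(=O)O[C@H](CC=C(C)C)C1=CC(=O)c2c(O)ccc(O)c2C1=O`, giving 72000 nM in this assay.

Compound 2 has the highest of the two numbers, the weaker inhibitor. Compound 3, `CC(C)=CC[C@@H](OC(=O)c1ccoc1)C1=CC(=O)c2c(O)ccc(O)c2C1=O`, differs from it by furan-3-yl in place of 2-hydroxy-2-methylpentyl on a carbonyl carbon. Going by the values given here, the only step known, a 4.2-fold higher number from compound 1 to compound 2 (0.63 log units; beyond the scatter), also changed the group on that carbonyl carbon, replacing a small saturated ring with the open hydroxylated chain and weakening the effect. Returning to a small ring, now aromatic, is expected to reverse part of that: a 3.3-fold lower number from compound 2 to compound 3 (0.51 log units; beyond the scatter) is expected. Compound 3 is therefore estimated at 22000 nM, in the range 8000 nM to 60000 nM.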

Compound 3, half-maximal inhibitory concentration: > 100000 nM
Compound 3: only a limit was reported; the forecaster's own chance of this, stated with the estimate: 10%; at least 4.5-fold (0.65 log units) between middle value and limit.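

Compound 3 reached only a limit of this assay, not a number: the limit of > 100000 nM in this assay, at which 1 of the 3 values shown sits.

This position therefore does not treat all small rings alike: going from oxolan-2-yl to furan-3-yl gives an at least 5.8-fold higher number from compound 1 to compound 3 (0.76 log units; beyond the scatter). Replacing the open chain with furan-3-yl gives an at least 1.3-fold higher number from compound 2 to compound 3 (0.14 log units; that floor lies within the scatter), so these two groups cannot yet be ranked against each other.

As far as these compounds go, it remains open how far the true value of compound 3 lies past the limit. Also open, from the compounds shown here alone, is whether a phenyl ring or an unbranched pentyl chain on this carbonyl carbon would fall nearer compound 1 or compound 3.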